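Ring size and attachment point at the ester of compound 3

The source may hold more compounds than are shown below. What is called first, only, known or untested is meant among the compounds shown, and "the series" means these compounds.

The measured compounds in a functional assay on DU-145 cells (Homo sapiens) for cytotoxicity, read by MTT assay (on this read-out lower numbers stand for stronger inhibition and higher numbers for weaker inhibition), are:
compound 1 `CCCCC(O)CC(=O)O[C@H](CC=C(C)C)C1=CC(=O)c2c(O)ccc(O)c2C1=O` with 45300 nM;
compound 2 `CC(=O)OCCO[C@H](CC=C(C)C)C1=CC(=O)c2c(O)ccc(O)c2C1=O` with 15500 nM;
compound 3 `CC(C)=CC[C@@H](OC(=O)C1CCOC1)C1=CC(=O)c2c(O)ccc(O)c2C1=O` with 47500 nM.

Compound 3 has the highest of the three numbers. Its nearest neighbour is compound 1, with a 1.0-fold higher number from compound 1 to compound 3 (0.02 log units; within the scatter), and its furthest is compound 2, with a 3.1-fold higher number from compound 2 to compound 3 (0.49 log units; beyond the scatter). Compound 4 `CC(C)=CC[C@@H](OC(=O)C1CCCCO1)C1=CC(=O)c2c(O)ccc(O)c2C1=O` is the unmeasured compound; the change from compound 3 reads (oxan-2-yl in place of oxolan-3-yl on a carbonyl carbon).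

For the measured compounds named here, only one measured step touches the same place: the exchange of 2-hydroxyhexyl for oxolan-3-yl on the carbonyl carbon gave a 1.0-fold higher number from compound 1 to compound 3 (0.02 log units; within the scatter). The steps of a 2.9-fold lower number from compound 1 to compound 2 (0.47 log units; beyond the scatter) and a 3.1-fold higher number from compound 2 to compound 3 (0.49 log units; beyond the scatter) replace the whole ester by a 2-acetoxyethyl group and so speak less directly to a change within the ring on the carbonyl carbon. Going by the values given here, because the one comparable step, a 1.0-fold higher number from compound 1 to compound 3 (0.02 log units; within the scatter), stayed within the scatter, compound 4 is expected to land near compound 3, with no step beyond the scatter, as a 1.1-fold lower number from compound 3 to compound 4 (0.02 log units; within the scatter). The estimate for compound 4 in this assay is 45000 nM, with a range from 20000 nM to 100000 nM.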

Compound 4, half-maximal inhibitory concentration: 24700 nM
Estimate against measurement, compound 4: 1.8-fold (0.26 log units) above, and the stated range covers the measured number.
By their numbers in this assay, from the lowest: compounds 2, 4, 1 and 3 (each within the scatter of the next, the first and the last beyond it).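

In this assay, oxan-2-yl in place of oxolan-3-yl on the carbonyl carbon gave a step that stays within the scatter (a 1.9-fold lower number from compound 3 to compound 4 (0.28 log units; within the scatter)), so this position has now taken two different exchanges without a step beyond it. Compound 4 also lies within the scatter of the two other esters' values, on both the step with the 2-acetoxyethyl compound (a 1.6-fold higher number from compound 2 to compound 4 (0.20 log units; within the scatter)) and the step with the 2-hydroxyhexyl compound (a 1.8-fold lower number from compound 1 to compound 4 (0.26 log units; within the scatter)), although compound 2 and compound 3 themselves lie beyond the scatter of each other. No measurement at hand accounts for these steps.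

Ring size and attachment point change together here, so their separate contributions remain open. Also open, as far as these compounds go, is whether a piperidine ring, carrying an amine in place of the ring oxygen, or a phenyl ring on this carbonyl carbon would move the number beyond the scatter.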